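Swapping one stereocentre in a camphor-derived sulfonyl group

This account rests on a few compounds, and the source may have more. Where it says the series, first, only, none or still open, it means among the compounds named here.

Compound 1 `CC1(C)C2CC[C@@]1(CS(=O)(=O)NC(=O)c1ccc(N3CCN(Cc4ccccc4-c4ccc(Cl)cc4)CC3)cc1)C(=O)C2` is measured in an assay on isolated protein for inhibition of Apoptosis regulator Bcl-2/Bcl-2 homologous antagonist/killer (Homo sapiens), read by surface plasmon resonance, with a stated time of 1 h (on this read-out higher numbers stand for an effect only at larger amounts of compound and lower numbers for an effect already at smaller amounts), where compound 1 gives 1470 nM. Two companions differ only in the group attached to the sulfonyl sulfur. Compound 2 `CC(C)(C)S(=O)(=O)NC(=O)c1ccc(N2CCN(Cc3ccccc3-c3ccc(Cl)cc3)CC2)cc1` carries a tert-butyl group there; in this assay compound 2 reaches only the limit > 16000 nM, which is a boundary of the measurement rather than a number (the limit of > 16000 nM in this assay, at which 1 of the 3 values shown sits). Compound 3 `CCS(=O)(=O)NC(=O)c1ccc(N2CCN(Cc3ccccc3-c3ccc(Cl)cc3)CC2)cc1` carries an ethyl group, and in this assay compound 3 gives 5310 nM. Among the numbers shown, compound 1 stands lowest; its nearest neighbour is compound 3 at a 3.6-fold higher number from compound 1 to compound 3 (0.56 log units; beyond the scatter), and the change to compound 2 is an at least 10-fold higher number from compound 1 to compound 2 (1.03 log units; beyond the scatter). Between the two small groups, an at least 3.0-fold lower number from compound 2 to compound 3 (0.47 log units; beyond the scatter).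

Compound 4 `CC1(C)C2CC[C@]1(CS(=O)(=O)NC(=O)c1ccc(N3CCN(Cc4ccccc4-c4ccc(Cl)cc4)CC3)cc1)C(=O)C2` keeps every atom and bond of compound 1: the two compounds have the same atoms and bonds; at least one stereo element is drawn with a configuration in one of them and without one in the other: 1 of 2 stereo elements differ; a stereocentre at a saturated ring carbon is drawn S in compound 1 and R in compound 4. Among the measured compounds shown here, none of the measured steps alters a stereocentre, so they bear on this change only indirectly, by showing that the bicyclic group itself carries a large part of the activity. For the measured compounds named here, a mirror-image arrangement of that group may therefore shift the number, but no step shows in which direction. The estimate for compound 4 in this assay is 2500 nM, with a range from 800 nM to 8000 nM, expected as the step of a 1.7-fold higher number from compound 1 to compound 4 (0.23 log units; within the scatter).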

Compound 4, half-maximal effective concentration: 1020 nM
Compound 4: the middle estimate sits 2.5-fold (0.39 log units) above what was measured; the measured number falls inside the stated range.
By their numbers in this assay, from the lowest: compounds 4 and 1 (each within the scatter of the next); then compound 3. At a limit, above all of these: compound 2.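

Inverting the stereocentre at the saturated ring carbon gives a 1.4-fold lower number from compound 1 to compound 4 (0.16 log units; within the scatter), so in this assay this position tolerates the change, and compounds 1 and 4 cannot be told apart. The advantage of the bicyclic group therefore does not depend on which of these two drawn configurations it carries: it holds up with compound 4 as it did with compound 1, as the comparison with the ethyl group shows, a 5.2-fold lower number from compound 3 to compound 4 (0.72 log units; beyond the scatter). The comparison with the tert-butyl group gives an at least 15-fold lower number from compound 2 to compound 4 (1.19 log units; beyond the scatter), but this step rests on a value for compound 2 that is a limit and not a number: the limit of > 16000 nM in this assay, at which 1 of the 4 values shown sits.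

The compounds shown leave open whether a simpler ring on the sulfonyl sulfur, such as cyclohexyl or phenyl, would do as well as the bicyclic group, or whether a longer chain such as n-butyl would close part of the gap to ethyl. The stereochemical comparison itself also needs to be read with one caution about how the two structures are drawn: the fact that one of compounds 1 and 4 is drawn with a defined configuration and the other without, at the place where they differ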